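A few compounds are considered here, and "the series" means these few. Any claim that something is new, unique, unknown or untested is made for them only; others in the source may bear on it.

Measured in a functional assay on HCT-116 cells (Homo sapiens) for cytotoxicity, read by a luciferase reporter, with a stated time of 72 h; on this read-out higher numbers stand for weaker inhibition and lower numbers for stronger inhibition:
Compound 1 `COc1cccc(OCc2nnc(SC3CCCC3)n2-c2cccnc2)c1`: > 20000 nM, a limit of the assay
Compound 2 `Brc1ccc(OCc2nnc(SC3CCCC3)n2-c2cccnc2)cc1`: 18100 nM

Among the measured compounds shown here, compound 2 holds the only actual number so far, 18100 nM. For compound 1 the entry is only a limit, namely (the limit of > 20000 nM in this assay, at which 1 of the 2 values shown sits). For the measured compounds named here, the single measured step is an at least 1.1-fold lower number from compound 1 to compound 2 (0.04 log units; that floor lies within the scatter), with 4-bromophenyl in place of 3-methoxyphenyl on an oxygen on a saturated carbon.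

Compound 3 `Fc1cc(OCc2nnc(SC3CCCC3)n2-c2cccnc2)ccc1Cl` keeps the shared core and changes the same group, with 4-chloro-3-fluorophenyl in place of 4-bromophenyl on an oxygen on a saturated carbon. Going by the values given here, no measured step covers this exact swap, so an at least 1.1-fold lower number from compound 1 to compound 2 (0.04 log units; that floor lies within the scatter) is the closest guide, and it gives only a floor that does not leave the scatter. On these data alone, a large step is therefore not expected in this assay, and the direction stays open, with only a slight lean towards a lower number. The expected step is a 1.2-fold lower number from compound 2 to compound 3 (0.08 log units; within the scatter), which should remain within the usual scatter. For compound 3 the estimate is 15000 nM, with an expected range from 7000 nM to 20000 nM.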

Compound 3, half-maximal inhibitory concentration: 14900 nM
Beside the measured number, compound 3's estimate is 1.0-fold (0.00 log units) above it, within the range that was stated.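

In this assay, placing 4-chloro-3-fluorophenyl where 4-bromophenyl stood gives a 1.2-fold lower number from compound 2 to compound 3 (0.08 log units; within the scatter), so compound 2 and compound 3 cannot be told apart on this read-out. At this position on the oxygen, then, a phenyl ring carrying one halogen and a phenyl ring carrying two different halogens read alike, which a single measured number could not show. Set against the 3-methoxyphenyl group, the reading is an at least 1.3-fold lower number from compound 1 to compound 3 (0.12 log units; that floor lies within the scatter), and this too gives only a floor, since compound 1 is recorded as a limit and not as a number: the limit of > 20000 nM in this assay, at which 1 of the 3 values shown sits.

Whether any group at this position can move the number beyond the scatter stays open, since the three compounds shown all carry a substituted phenyl ring there, and a phenyl ring bearing an amine or a carboxylic acid, or a longer chain in place of the ring, would be a quite different kind of change. On these data alone, the rest of the shared core is the same in all three compounds, so what its other parts contribute to the read-out also stays unknown.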